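The source may hold more compounds than are shown below. What is called first, only, known or untested is meant among the compounds shown, and "the series" means these compounds.

In an assay on cells for inhibition of HSP60/HSP10 (Homo sapiens), with a stated time of 60 min (on this read-out higher numbers stand for weaker inhibition and lower numbers for stronger inhibition), two compounds have been measured and one remains to be tested. Compound 1 `O=S(=O)(Nc1ccc2oc(-c3ccccc3)nc2c1)c1ccccc1F` gives > 100000 nM, which is a limit of the assay and not a number. Compound 2 `O=S(=O)(Nc1ccc(-c2nc3ccccc3o2)cc1)c1ccccc1F` gives > 100000 nM, again a limit rather than a measured value. Compound 2 therefore stands exactly where everything measured so far stands, at the limit of > 100000 nM in this assay, at which 2 of the 2 values shown sit, and nothing separates it from compound 1 on the numbers shown. Compound 3 `O=S(=O)(Nc1ccc(-c2nc3cc(NS(=O)(=O)c4ccccc4F)ccc3o2)cc1)c1ccccc1F` differs from compound 2 by ((2-fluorophenyl)sulfonyl)amino in place of hydrogen on an aromatic carbon. Among the measured compounds shown here, no step between measured compounds exists to guide the size of this change, so the expectation rests only on the two limits. Because both measured values sit at the limit of > 100000 nM in this assay, at which 2 of the 2 values shown sit, the step from compound 2 to compound 3 is expected to be small, a number no higher from compound 2 to compound 3 (the limit leaves the size open), in no clear direction beyond the scatter. Compound 3 is accordingly estimated at 100000 nM, within 20000 nM to 300000 nM, most likely reported once more as a limit.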

Compound 3, half-maximal inhibitory concentration: 57000 nM
Compound 3: middle estimate off by 1.8-fold (0.24 log units), on the high side; low and high end bracket the measured number.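

In this assay, compound 3 is the first compound shown to give a number rather than a limit, so ((2-fluorophenyl)sulfonyl)amino on this aromatic carbon, meta to a fused ring and para to a fused ring, brings the read-out onto the measurable scale. The change reads as an at least 1.7-fold lower number from compound 2 to compound 3 (0.24 log units; that floor lies within the scatter), and the comparison with the other limit reads as an at least 1.7-fold lower number from compound 1 to compound 3 (0.24 log units; that floor lies within the scatter). Each of these is only a floor, so the true size of the step stays unknown, and the other two compounds remain at the limit: the limit of > 100000 nM in this assay, at which 2 of the 3 values shown sit.

The compounds shown leave open whether a smaller group on this carbon, such as a plain amine or an acetamide, would also give a number, or whether the whole ((2-fluorophenyl)sulfonyl)amino is needed. Also open, on these data alone, is whether a plain phenylsulfonylamino group, without the fluorine, would match compound 3 at 57000 nM.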